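This account rests on a few compounds, and the source may have more. Where it says the series, first, only, none or still open, it means among the compounds named here.

For the measured compounds named here, in a functional assay on A549 cells (Homo sapiens) for inhibition, read by MTT assay, with a stated time of 72 h (a lower number here means a stronger inhibitor, a higher number a weaker inhibitor), three compounds have numbers so far. Compound 1 (`COc1cc2c(Oc3ccc(NC(=O)c4nn(-c5ccccc5C)cc(C)c4=O)cc3)ccnc2cc1OCCCC(=O)NO`) gives 4460 nM, compound 3 (`COc1cc2c(Oc3ccc(NC(=O)c4nn(-c5ccccc5C)cc(C)c4=O)cc3F)ccnc2cc1OCCCC(=O)NO`) gives 2090 nM, and compound 2 (`COc1cc2c(Oc3ccc(NC(=O)c4nn(-c5ccc(F)c(Cl)c5)cc(C)c4=O)cc3)ccnc2cc1OCCCCCCC(=O)NO`) gives 380 nM. That last number is the lowest of the three, and its gaps to the other two lie beyond the usual scatter of repeat measurements.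

Compound 4 (`COc1cc2c(Oc3ccc(NC(=O)c4nn(-c5ccccc5)cc(C)c4=O)cc3)ccnc2cc1OCCCCCCC(=O)NO`) has not been measured yet. It keeps everything in compound 2 except one group on an aromatic nitrogen, where phenyl stands in place of 3-chloro-4-fluorophenyl: phenyl in place of 3-chloro-4-fluorophenyl on an aromatic nitrogen.

Going by the values given here, only one measured step bears on this change, and only loosely, since no measured pair tests this group directly. Going by a 2.1-fold lower number from compound 1 to compound 3 (0.33 log units; beyond the scatter), a modest step in which fluoro replaces hydrogen on an aromatic carbon elsewhere in the molecule, a modest rise in this assay is expected when fluoro and chloro both leave.

Compound 4 is estimated at 650 nM, with an expected range of 250 nM to 1600 nM. The estimated change is a 1.7-fold higher number from compound 2 to compound 4 (0.23 log units; within the scatter).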

Compound 4, half-maximal inhibitory concentration: 420 nM
For compound 4 the middle estimate is 1.5-fold (0.19 log units) above the measured one, within the range that was stated.
By their numbers in this assay, from the lowest: compounds 2 and 4 (each within the scatter of the next); then compound 3; then compound 1.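

Putting phenyl in place of 3-chloro-4-fluorophenyl on the aromatic nitrogen gives a 1.1-fold higher number from compound 2 to compound 4 (0.04 log units; within the scatter) in this assay, so here the chloro and fluoro can both leave without a change that stands out from repeat scatter. For the compounds shown here, the only earlier halogen step, a 2.1-fold lower number from compound 1 to compound 3 (0.33 log units; beyond the scatter), lies beyond the scatter but sits elsewhere in the molecule, so for these compounds that step does not carry over to this position. Nothing measured here explains why the two steps differ.

The compounds shown leave open how this position would respond to an amine or a carboxylic acid on the phenyl, or to a methyl in place of the whole ring. They also leave open whether the same small step would appear with the chain of compound 1.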